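A few compounds are considered here, and "the series" means these few. Any claim that something is new, unique, unknown or untested is made for them only; others in the source may bear on it.

Two compounds with a shared core give actual numbers in a functional assay on MCF7 cells (Homo sapiens) for antiproliferative activity, read by MTT assay, with a stated time of 72 h; on this read-out lower numbers stand for stronger inhibition and higher numbers for weaker inhibition. Compound 2 `C=CC(=O)Nc1cccc(Oc2nc(Nc3ccc(OC)cc3)nc3c2CSCC3)c1` gives 11700 nM. Compound 3 `C/C=C/C(=O)Nc1cccc(Oc2nc(Nc3ccc(OC)cc3)nc3c2CSCC3)c1` gives 24300 nM, the higher of these two numbers, and so it is the weaker inhibitor of the pair. Compound 1 `COc1cccc(Nc2nc3c(c(Oc4cccc(NC(=O)C=C(C)C)c4)n2)CSCC3)c1`, which also carries 2-methylprop-1-en-1-yl on a carbonyl carbon, gives > 50000 nM, and this is a limit of the assay and not a number.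

Compound 4 `COc1ccc(Nc2nc3c(c(Oc4cccc(NC(=O)C=C(C)C)c4)n2)CSCC3)cc1` is compound 3 with a single change: 2-methylprop-1-en-1-yl in place of prop-1-en-1-yl on a carbonyl carbon. In words, 2-methylprop-1-en-1-yl takes the place of prop-1-en-1-yl on a carbonyl carbon, with an amide-type nitrogen as the other neighbour.

For the measured compounds named here, one measured step bears directly on this change. Putting prop-1-en-1-yl in place of vinyl on a carbonyl carbon gave a 2.1-fold higher number from compound 2 to compound 3 (0.32 log units; beyond the scatter), which is a modest move toward weaker inhibition. A single step is thin ground, but a further modest move in the same direction is the reasonable expectation. The expected change is a 1.7-fold higher number from compound 3 to compound 4 (0.24 log units; within the scatter), toward a higher number in this assay. A result reported only as a limit is also a real possibility for compound 4. The estimated value for compound 4 is 42000 nM, with an expected range from 22000 nM to 70000 nM.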

Compound 4, half-maximal inhibitory concentration: > 50000 nM
Compound 4: a limit, no number; the forecaster's own chance of this, stated with the estimate: 45%; middle value at least 1.1-fold (0.07 log units) away from the limit.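

On the carbonyl carbon whose other neighbour is the amide-type nitrogen, 2-methylprop-1-en-1-yl carries on the drift that prop-1-en-1-yl began: in this assay the new step is an at least 2.0-fold higher number from compound 3 to compound 4 (0.31 log units; beyond the scatter), and the whole move away from vinyl is an at least 4.2-fold higher number from compound 2 to compound 4 (0.63 log units; beyond the scatter). Vinyl, prop-1-en-1-yl and 2-methylprop-1-en-1-yl, in that order, therefore give weaker and weaker inhibition across compound 2, compound 3 and compound 4, and none of these three goes against that order. Compound 4 gives a limit of the assay and not a number, so both steps are minimum sizes, and the weak end of this short series now rests on a single ceiling: the limit of > 50000 nM in this assay, at which 2 of the 4 values shown sit.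

Going by these compounds, the step between compound 1 and compound 4 cannot be read, so what 4-methoxyphenyl in place of 3-methoxyphenyl does in this setting stays unknown. Also open, on these data alone, is whether a group of another kind on the same carbonyl carbon, such as a saturated ethyl group or a longer chain ending in an amine, would bring the number back down.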